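This account rests on a few compounds, and the source may have more. Where it says the series, first, only, none or still open, it means among the compounds named here.

Of the compounds shown here, three have been measured in a functional assay on aorta (Rattus norvegicus) for inhibition; on this read-out lower numbers stand for an effect already at smaller amounts and higher numbers for an effect only at larger amounts of compound. Compound 1 `O=S1(=O)N=C(NC2CCC2)Nc2c(Cl)cccc21` gives 126000 nM, compound 2 `CCNC1=NS(=O)(=O)c2ccc(Cl)cc2N1` gives 54800 nM, and compound 3 `CCCNC1=NS(=O)(=O)c2ccc(Cl)cc2N1` gives 73200 nM. Compound 3 stands within the scatter of both compound 2, its nearest neighbour on these numbers, and compound 1, its furthest, so its place among them carries little weight.

The next compound to be measured is compound 4 `CC(C)NC1=NS(=O)(=O)c2ccc(Cl)cc2N1`, which has the same atoms as compound 3, joined differently: isopropyl in place of propyl on an amine nitrogen. In words, this is isopropyl in place of propyl on an amine nitrogen.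

Among the compounds with values here, only one measured step touches this chain: methyl in place of hydrogen on a saturated chain carbon, two bonds along the chain from an amine nitrogen. This is a 1.3-fold higher number from compound 2 to compound 3 (0.13 log units; within the scatter). Within the data shown here, that step stays within the scatter, but it is only indirect evidence, since no measured compound carries isopropyl. With this single small step as the guide, no change beyond the scatter is expected in this assay, and no direction is favoured. The expected step is a 1.1-fold lower number from compound 3 to compound 4 (0.03 log units; within the scatter). In this assay, the estimated value for compound 4 is 68000 nM, with an expected range of 34000 nM to 135000 nM.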

Compound 4, half-maximal effective concentration: 53400 nM
Beside the measured number, compound 4's estimate is 1.3-fold (0.10 log units) above it, and the stated range covers the measured number.
By their numbers in this assay, from the lowest: compounds 4, 2, 3 and 1 (each within the scatter of the next, the first and the last beyond it).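

In this assay, within the data shown here, the result gives the first direct reading of a branched group on this amine nitrogen: the swap of propyl for isopropyl keeps the same count of heavy atoms and amounts to a 1.4-fold lower number from compound 3 to compound 4 (0.14 log units; within the scatter), so rearranging these carbons does not move the number beyond the scatter. The other new comparison, methyl in place of hydrogen on the saturated chain carbon bound to the amine nitrogen and a saturated chain carbon, is a 1.0-fold lower number from compound 2 to compound 4 (0.01 log units; within the scatter), which means that across the three compounds with these small chains, neither the added carbon nor the branch separates them on this read-out. No supporting evidence is available that bears on this result or could account for it.

The compounds shown leave open whether a longer chain such as butyl, a more heavily branched tert-butyl group, or a chain ending in a hydroxyl group or an amine on this nitrogen would give a step beyond the scatter. Compound 1 carries a ring on the same nitrogen but also differs from the others in a second place, so the effect of a ring at this position remains unresolved.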